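Ethyl for acetamido on the ring nitrogen of a rhodanine

The source may hold more compounds than are shown below. What is called first, only, known or untested is meant among the compounds shown, and "the series" means these compounds.

Measured so far:
compound 1 `CC(=O)NN1C(=O)/C(=C/c2ccccc2)SC1=S` — "not active" (no number reported)
compound 2 `O=C1/C(=C/c2cn(-c3ccccc3)nc2-c2cccs2)SC(=S)N1C1CCS(=O)(=O)C1` — 117000 nM

Of the compounds shown here, two have been tested in an assay for inhibition of LL-diaminopimelate aminotransferase, chloroplastic (Arabidopsis thaliana); on this read-out lower numbers stand for stronger inhibition and higher numbers for weaker inhibition. Compound 1 `CC(=O)NN1C(=O)/C(=C/c2ccccc2)SC1=S` gave no number: in this assay compound 1 is reported as "not active" (no number reported), so no single value marks where it stands. Compound 2 `O=C1/C(=C/c2cn(-c3ccccc3)nc2-c2cccs2)SC(=S)N1C1CCS(=O)(=O)C1`, built on a different pattern of substituents, gave a measurable but weak result; in this assay compound 2 reaches 117000 nM. Compound 3 `CCN1C(=O)/C(=C/c2ccccc2)SC1=S` has not yet been measured. It differs from compound 1 in one place: ethyl in place of acetamido on an amide-type nitrogen in a ring. Among the measured compounds shown here, no step between measured compounds shows what such a swap does, so the size and direction of the change are open; with compound 1 showing "not active" (no number reported), only a weak result seems plausible. For compound 3 the estimate is 150000 nM, expected between 40000 nM and 600000 nM.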

Compound 3, half-maximal inhibitory concentration: > 200000 nM
Compound 3: a limit, no number; the forecaster's own chance of this, stated with the estimate: 60%; at least 1.3-fold (0.12 log units) between middle value and limit.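

Compound 3 gives > 200000 nM in this assay, which is a limit and not a number. Among the compounds shown here, compound 1 also has no number, and no step between compound 1 and compound 3 can be read. The compounds shown leave open how ethyl and acetamido on an amide-type nitrogen in a ring compare.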